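Amide series: cytotoxicity notes at the assay limit

The source may report more compounds than this note shows. Statements on the series, on what has been measured and on what is new or still open speak of the compounds shown alone.

compound 1 `CN(Cc1cccc(F)c1)C(=O)CCCNC(=O)c1ccc(S(C)(=O)=O)c([N+](=O)[O-])c1`: > 27000 nM
compound 2 `CS(=O)(=O)c1ccc(C(=O)NCCC(=O)N2CCCCC2)cc1[N+](=O)[O-]`: > 27000 nM

In an ADME assay on HepG2 cells (Homo sapiens) for cytotoxicity, read by CellTiter-Glo and ATP content, with a stated time of 72 h (a higher number here means that more compound is needed for the effect, a lower number that less compound is needed), compound 1 gives only a limit, > 27000 nM. In this assay compound 2 likewise gives only a limit, > 27000 nM. Both results sit at the limit of > 27000 nM in this assay, at which 2 of the 2 values shown sit, so compound 2 cannot be placed by a number against compound 1. Compound 3 `CS(=O)(=O)c1ccc(C(=O)NCCC(=O)N2CCCc3ccccc32)cc1[N+](=O)[O-]` differs from compound 2 by 1,2,3,4-tetrahydroquinolin-1-yl in place of piperidin-1-yl on a carbonyl carbon. For the measured compounds named here, no measured step between two compounds is available for comparison. No step beyond the scatter is expected in this assay from compound 2 to compound 3, the estimate being a step that the limit leaves unreadable from compound 2 to compound 3. Compound 3 is expected at 40000 nM, within 15000 nM to 120000 nM, most likely again reported only as a limit.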

Compound 3, half-maximal effective concentration: 10500 nM
Compound 3: middle estimate off by 3.8-fold (0.58 log units), on the high side; measured number below the stated range.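

For the compounds shown here, replacing piperidin-1-yl with 1,2,3,4-tetrahydroquinolin-1-yl on the carbonyl carbon gives an at least 2.5-fold lower number from compound 2 to compound 3 (0.41 log units; beyond the scatter) in this assay and yields the only value shown that is not a limit. The earlier pair, both limits, could not show that this position responds to a change of ring. From the compounds shown here alone, the true size of the step stays unknown because compound 2 sits at a limit: the limit of > 27000 nM in this assay, at which 2 of the 3 values shown sit.

The compounds shown leave open whether the fused aromatic ring or the larger group accounts for the step. Going by these compounds, how a morpholin-4-yl or indolin-1-yl group would read at this place also remains open.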